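The source may report more compounds than this note shows. Statements on the series, on what has been measured and on what is new or still open speak of the compounds shown alone.

Measured so far:
compound 1, `CCCN(CCC)CCCOc1ccc2cc(NC(=O)c3ccc(O)c(CC=C(C)C)c3)c(=O)oc2c1C`; compound 2, `CC(C)=CCc1cc(C(=O)Nc2cc3ccc(OCCCNCCO)c(C)c3oc2=O)ccc1O`.

In a functional assay on SK-BR-3 cells (Homo sapiens) for antiproliferative activity (a lower number here means a stronger inhibitor, a higher number a weaker inhibitor), compound 1 gives only a limit, > 50000 nM. In this assay, among the measured compounds shown here, compound 2 gives 610 nM, the only number among the two values shown. The step from compound 1 to compound 2 is an at least 81-fold lower number from compound 1 to compound 2 (1.91 log units; beyond the scatter), and the evidence on it is the limit of > 50000 nM in this assay, at which 1 of the 2 values shown sits.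

Compound 3, `CC(C)=CCc1cc(C(=O)Nc2cc3ccc(OCCCN(C)Cc4ccccc4)c(C)c3oc2=O)ccc1O`, differs from compound 2 by benzyl(methyl)amino in place of (2-hydroxyethyl)amino on a saturated chain carbon, three bonds along the chain from an oxygen on an aromatic ring.

For the measured compounds named here, the one measured step that bears on this change is the step from compound 1 to compound 2: there a dipropylamino at this place gave only a limit, and the (2-hydroxyethyl)amino gave a measurable number, a large step. Compound 3 returns to a tertiary amine at the same place, now as benzyl(methyl)amino. On that single step, the expectation for this assay is a step back toward the weaker side, of a size comparable to the measured one, with a real chance that only a limit is reported. The estimate for compound 3 is therefore 10000 nM, range 1500 nM to 50000 nM, an expected step of a 16-fold higher number from compound 2 to compound 3 (1.21 log units; beyond the scatter).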

Compound 3, half-maximal inhibitory concentration: 10700 nM
Compound 3: middle estimate off by 1.1-fold (0.03 log units), on the low side; low and high end bracket the measured number.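

In this assay, the new compound separates two tertiary amines on the saturated chain carbon, three bonds along the chain from an oxygen on an aromatic ring: benzyl(methyl)amino in place of dipropylamino gives an at least 4.6-fold lower number from compound 1 to compound 3 (0.66 log units; beyond the scatter), so a tertiary amine at this place can still give a measurable number. Against (2-hydroxyethyl)amino, benzyl(methyl)amino gives an 18-fold higher number from compound 2 to compound 3 (1.24 log units; beyond the scatter), which leaves compound 2 as the strongest of the three and shows that the large gap at this place is not confined to the pair with dipropylamino. The gain over dipropylamino is only a lower bound, as compound 1 is a limit: the limit of > 50000 nM in this assay, at which 1 of the 3 values shown sits.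

On these data alone, the change from compound 2 to compound 3 alters the hydroxyl, the hydrogen on the nitrogen and the benzyl ring together, so the share of each in the step stays open; (2-hydroxyethyl)(methyl)amino and benzylamino at this place would pull them apart. Also open, as far as these compounds go, is how a cyclic amine such as morpholine or piperazine, or a longer chain carrying (2-hydroxyethyl)amino, would read in this assay.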